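The compounds below may be only part of what the source reports. "The series", "measured", "known", "first", "only" and "open" are said of these compounds alone.

Compound 1, `CCc1nc(NC(CC)CC)c(F)nc1-c1ccc(Cl)cc1Cl`: 167 nM
Compound 2, `CCc1nc(-c2ccc(Cl)cc2Cl)c(CC)nc1CC(CC)CC`: 68 nM

In an assay on IMR-32 cells for displacement of a labelled ligand from corticotropin-releasing factor receptor 1 (Homo sapiens), read by scintillation counting, with a stated time of 2 h (on this read-out lower numbers stand for stronger inhibition and higher numbers for weaker inhibition), compound 1 gives 167 nM, the highest of the two numbers shown. Its nearest neighbour, compound 2, gives 68 nM, and that gap lies beyond the scatter. Compound 3, `CCc1nc(NC(CC)CC)c(I)nc1-c1ccc(Cl)cc1Cl`, has not yet been measured. It differs from compound 1 in one place: iodo in place of fluoro on an aromatic carbon. Within the data shown here, no measured pair carries this same change, so any expectation rests on the change itself. The step of a 2.0-fold lower number from compound 1 to compound 3 (0.29 log units; within the scatter) is expected to be small and toward a lower number, possibly no larger than the scatter. Compound 3 is therefore estimated at 85 nM, within a range from 25 nM to 300 nM.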

Compound 3, inhibition constant: 12 nM
Estimate against measurement, compound 3: 7.1-fold (0.85 log units) above; measured number outside the range, below it.
By their numbers in this assay, from the lowest: compound 3; then compound 2; then compound 1.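

The position para to an ethyl group on the core of compound 1 proves sensitive to which halogen it carries: in this assay, iodo in place of fluoro gives a 14-fold lower number from compound 1 to compound 3 (1.14 log units; beyond the scatter). Exchanging one heavy atom for another, with no hydrogen-bond donor or acceptor entering or leaving, is enough to produce a step of this size. No measurement shown here accounts for it.

As far as these compounds go, whether chloro or bromo at this position would fall between fluoro and iodo remains open. So does whether a non-halogen group, such as a nitrile or a methyl group, could match iodo.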